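From a triazole diol to a piperazine chain

The source may report more compounds than this note shows. Statements on the series, on what has been measured and on what is new or still open speak of the compounds shown alone.

In a functional assay on A-375 cells (Homo sapiens) for cytotoxicity, read by MTT assay, with a stated time of 72 h (a lower number here means a stronger inhibitor, a higher number a weaker inhibitor), compound 1 `CN(C)CCCCCn1c2c(c3ccccc31)C(=O)c1c[n+]([O-])c3ccccc3c1C2=O` gives 560 nM, compound 2 `CCCCN1CCN(CCCCn2c3c(c4ccccc42)C(=O)c2c[n+]([O-])c4ccccc4c2C3=O)CC1` gives 2150 nM and compound 3 `O=C1c2c[n+]([O-])c3ccccc3c2C(=O)c2c1c1ccccc1n2Cc1cn(C[C@@H](O)CO)nn1` gives 140 nM, the lowest of the three numbers. Compound 4 `CN1CCN(CCCCCn2c3c(c4ccccc42)C(=O)c2c[n+]([O-])c4ccccc4c2C3=O)CC1` has 4-(4-methylpiperazin-1-yl)butyl in place of 1-(2,3-dihydroxypropyl)-1H-1,2,3-triazol-4-yl on a saturated chain carbon bound to an aromatic nitrogen. Going by the values given here, two measured steps bear on this change. The triazole group brought a 4.0-fold lower number from compound 1 to compound 3 (0.60 log units; beyond the scatter), so removing it should raise the number. The 4-butylpiperazin-1-yl group brought a 3.8-fold higher number from compound 1 to compound 2 (0.58 log units; beyond the scatter), which suggests that a piperazine chain may not recover that loss. A rise beyond the scatter is therefore expected, and the estimated step is a 7.1-fold higher number from compound 3 to compound 4 (0.85 log units; beyond the scatter). For compound 4 the estimate is 1000 nM, with an expected range of 350 nM to 2800 nM.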

Compound 4, half-maximal inhibitory concentration: 1710 nM
Compound 4: the middle estimate sits 1.7-fold (0.23 log units) below what was measured, and the stated range covers the measured number.
By their numbers in this assay, from the lowest: compound 3; then compound 1; then compounds 4 and 2 (each within the scatter of the next).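

In this assay, the 4-(4-methylpiperazin-1-yl)butyl group gives up far more than the triazole diol provided at this chain carbon (a 12-fold higher number from compound 3 to compound 4 (1.09 log units; beyond the scatter)). Two different piperazine chains show no separable difference (a 1.3-fold lower number from compound 2 to compound 4 (0.10 log units; within the scatter)), whereas 4-methylpiperazin-1-yl in place of dimethylamino at the chain end does shift the number (a 3.1-fold higher number from compound 1 to compound 4 (0.48 log units; beyond the scatter)). No measured evidence accounts for these differences. The compounds shown leave open whether a morpholine or a primary amine at the end of the chain would come closer to compound 3.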